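The compounds below may be only part of what the source reports. "The series", "measured", "known", "first", "only" and "open" are said of these compounds alone.

In a functional assay on K562 cells (Homo sapiens) for antiproliferative activity, read by MTT assay, with a stated time of 24 h (on this read-out higher numbers stand for weaker inhibition and lower numbers for stronger inhibition), the measured compounds are:

- Compound 1 `COc1ccc(C(=O)/C=C/c2ccc(N(C)C)cc2)c2c1C=CC(C)(C)O2`: 3500 nM
- Compound 2 `COc1ccc(C(=O)/C=C/c2ccc([N+](=O)[O-])cc2)c2c1C=CC(C)(C)O2`: 7770 nM
- Compound 3 `COc1ccc(C(=O)/C=C/c2cccc([N+](=O)[O-])c2)c2c1C=CC(C)(C)O2`: 5870 nM

Compound 3 holds the middle number of the three, and its steps to the other two stay within the scatter: a 1.7-fold higher number from compound 1 to compound 3 (0.22 log units; within the scatter) and a 1.3-fold lower number from compound 2 to compound 3 (0.12 log units; within the scatter). Compound 4 `COc1ccc(C(=O)/C=C/c2ccccc2)c2c1C=CC(C)(C)O2` differs from compound 3 by hydrogen in place of nitro on an aromatic carbon. For the measured compounds named here, no measured step makes this exact change. The closest evidence is a 1.3-fold lower number from compound 2 to compound 3 (0.12 log units; within the scatter), within the scatter, and a 2.2-fold higher number from compound 1 to compound 2 (0.35 log units; beyond the scatter), a modest step. In this assay, no step beyond the scatter is therefore expected. The estimated step is a 1.2-fold lower number from compound 3 to compound 4 (0.07 log units; within the scatter). For compound 4, the expected value is 5000 nM, with an estimated range of 2500 nM to 10000 nM.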

Compound 4, half-maximal inhibitory concentration: > 10000 nM
Compound 4: no number, only a limit; the forecaster's own chance of this, stated with the estimate: 2%; middle value at least 2.0-fold (0.30 log units) away from the limit.
By their numbers in this assay, from the lowest: compounds 1, 3 and 2 (each within the scatter of the next, the first and the last beyond it). At a limit, above all of these: compound 4.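

In this assay the value of compound 4, > 10000 nM, is a limit and not a number. Replacing nitro with hydrogen on this aromatic carbon brought no measurable gain: the change gives an at least 1.7-fold higher number from compound 3 to compound 4 (0.23 log units; that floor lies within the scatter) and an at least 1.2-fold higher number from compound 2 to compound 4 (0.10 log units; that floor lies within the scatter), and both floors lie within the scatter, so neither step is established as a real loss. For the compounds shown here, only an at least 2.8-fold higher number from compound 1 to compound 4 (0.45 log units; beyond the scatter) passes the scatter, which shows for the first time that the bare phenyl ring falls clearly behind the dimethylamino-bearing ring.

Going by these compounds, how far compound 4 lies past its limit stays open: the limit of > 10000 nM in this assay, at which 1 of the 4 values shown sits. Also open is what an amine or a carboxylic acid would give in place of the nitro.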